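A few compounds are considered here, and "the series" means these few. Any claim that something is new, unique, unknown or untested is made for them only; others in the source may bear on it.

Measured in an ADME assay on L6 cells (Rattus norvegicus) for cytotoxicity, read by resazurin assay, with a stated time of 72 h; on this read-out lower numbers stand for stronger inhibition and higher numbers for weaker inhibition:
- compound 1 `O=C(NC(=O)c1ccccc1O)c1ccc(OC(F)(F)F)cc1`: 84 ug/mL
- compound 2 `CCOc1ccc(C(=O)NC(=O)c2ccccc2O)cc1`: 17 ug/mL

Of the two measured compounds, compound 2 has the lower number, at 17 ug/mL, and so shows the stronger inhibition in this assay. The next entry is compound 3 `O=C(NC(=O)c1ccccc1O)c1ccc(OCc2ccccc2)cc1`, which has phenyl in place of methyl on a saturated chain carbon bound to an oxygen on an aromatic ring, so that ethoxy becomes benzyloxy: phenyl in place of methyl on a saturated chain carbon bound to an oxygen on an aromatic ring.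

Going by the values given here, only one measured step bears on this change, and only indirectly: a 4.9-fold lower number from compound 1 to compound 2 (0.69 log units; beyond the scatter). That step also changes the group on the oxygen, but it replaces trifluoromethyl with ethyl, so it is a different substitution. It sets a modest scale and went toward a lower number, but a single pair cannot establish a trend. A step of no greater size is therefore expected, most likely within the scatter and leaning slightly toward a lower number. The estimated step is a 1.4-fold lower number from compound 2 to compound 3 (0.15 log units; within the scatter). For compound 3 the expected value is 12 ug/mL, with an expected range of 4 ug/mL to 40 ug/mL.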

Compound 3, half-maximal inhibitory concentration: 64 ug/mL
Estimate against measurement, compound 3: 5.3-fold (0.73 log units) below, and the stated range ends below it.
By their numbers in this assay, from the lowest: compound 2; then compounds 3 and 1 (each within the scatter of the next).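

In this assay the phenyl on the saturated chain carbon gives a 3.8-fold higher number from compound 2 to compound 3 (0.58 log units; beyond the scatter) and so takes away the low number seen with ethyl, which shows that this position does respond to a change beyond the ethyl group. Benzyl and trifluoromethyl on the oxygen read alike, with a 1.3-fold lower number from compound 1 to compound 3 (0.12 log units; within the scatter) and so within the scatter, leaving compound 2 alone apart from the other two compounds. Nothing on hand gives a reason for the response to benzyl at this position.

Going by these compounds alone, with ethyl and benzyl as the only carbon-chain groups on this oxygen, it stays open whether the low number belongs to short chains in general or to ethyl alone, and a propyl or butyl chain would help to settle that. As far as these compounds go, it also stays open whether the effect of the added phenyl comes with any aromatic ring on this carbon, and a pyridine ring or a cyclohexyl ring in its place would separate those readings.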